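This account rests on a few compounds, and the source may have more. Where it says the series, first, only, none or still open, it means among the compounds named here.

Measured so far in a physicochemical assay for lipophilicity, at pH 7.4; a higher number here means a more lipophilic compound, a lower number a more polar compound:
- compound 1 `CCc1ccc(N(CC2CC2)S(=O)(=O)c2ccc3c(c2)C(=O)CC(C2CCOCC2)O3)cc1` gives 3.77
- compound 2 `CCc1ccc(N(CC(C)C)S(=O)(=O)c2ccc3c(c2)C(=O)CC(C(C)C2CCOCC2)O3)cc1` gives 4.93
- compound 3 `CC(C)CN(c1ccc(F)cc1F)S(=O)(=O)c1ccc2c(c1)C(=O)CC(C1CCOCC1)O2` gives 3.62

Compound 3 lies within the scatter of compound 1 and well under compound 2, a gap beyond the scatter. Compound 4 `CCc1ccc(N(CC(C)C)S(=O)(=O)c2ccc3c(c2)C(=O)CC(C2CCOCC2)O3)cc1` differs from compound 3 in one place, with 4-ethylphenyl in place of 2,4-difluorophenyl on a sulfonamide nitrogen. Within the data shown here, no measured pair shows this change alone. Compound 1 (3.77) and compound 2 (4.93) both carry 4-ethylphenyl but differ from compound 4 elsewhere, and compound 4 is expected to fall between them. A rise beyond the scatter in this assay is expected, an estimated step (a number 0.53 log units higher from compound 3 to compound 4 (beyond the scatter)). Compound 4 is estimated at 4.15 within a range of 3.85 to 4.5 on this reading.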

Compound 4, distribution coefficient: 4.21
Compound 4: the middle estimate sits 0.06 log units below what was measured; the measured number falls inside the stated range.
By their numbers in this assay, from the lowest: compounds 3 and 1 (each within the scatter of the next); then compound 4; then compound 2.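

In this assay, 4-ethylphenyl in place of 2,4-difluorophenyl on a sulfonamide nitrogen now has a single-change reading, a number 0.59 log units higher from compound 3 to compound 4 (beyond the scatter) with nothing else altered. Compound 4 also isolates two other changes: isopropyl in place of cyclopropyl on a saturated chain carbon bound to a sulfonamide nitrogen gives a number 0.44 log units higher from compound 1 to compound 4 (beyond the scatter) and oxan-4-yl in place of 1-(oxan-4-yl)ethyl on a saturated ring carbon gives a number 0.72 log units lower from compound 2 to compound 4 (beyond the scatter) as well. Each single change therefore moves the number beyond the scatter.

From the compounds shown here alone, how a phenyl group carrying an amine or a carboxylic acid would read on that sulfonamide nitrogen remains open. Nothing available explains any of these steps.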